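The compounds below may be only part of what the source reports. "The series", "measured", "known", "first", "only" and "open" are said of these compounds alone.

Measured compounds:
Compound 1 `CS(=O)(=O)c1ccc(F)cc1C(=O)N1CCC(N(C2CC2)S(=O)(=O)c2ccccc2C(F)(F)F)CC1` — 17%
Compound 2 `NC(=O)c1ccc(C(=O)N2CCC(N(C3CC3)S(=O)(=O)c3cccc(C(F)(F)F)c3)CC2)cc1` — 12%
Compound 3 `CS(=O)(=O)c1ccc(C(=O)N2CCC(N(C3CC3)S(=O)(=O)c3cccc(C(F)(F)F)c3)CC2)cc1` — 52%

In an assay on HEK293 cells for inhibition of Voltage-dependent N-type calcium channel subunit alpha-1B (Homo sapiens), read by FLIPR and calcium flux, tested at 1 uM (a lower number here means less inhibition, a higher number more inhibition at the concentration tested (going by the name of the read-out)), compound 1 gives the second highest of the three numbers. Compound 2 sits nearest, within the usual scatter. Within the data shown here, compound 3 sits furthest, and the one step so far is a number 40 percentage points higher from compound 2 to compound 3 (beyond the scatter), which concerns a change on the aromatic carbon of the benzamide part of the shared core, not the sulfonyl side.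

Compound 4 `CS(=O)(=O)c1ccc(F)cc1C(=O)N1CCC(N(C2CC2)S(=O)(=O)c2ccc(OC(F)(F)F)cc2)CC1` differs from compound 1 in one place: 4-(trifluoromethoxy)phenyl in place of 2-(trifluoromethyl)phenyl on a sulfonyl sulfur. Among the measured compounds shown here, no measured step touches the group on the sulfonyl sulfur, so nothing here speaks for a change beyond the scatter in this assay. Compound 4 is therefore expected to give 17%, between 3% and 40%. The estimated step is no change at the digits printed from compound 1 to compound 4 (within the scatter).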

Compound 4, a percentage reported as inhibition, at one concentration (the size of the read-out at that concentration, not a potency): 0%
Beside the measured number, compound 4's estimate is 17 percentage points above it; measured number outside the range, below it.
By their numbers in this assay, from the lowest: compound 4; then compounds 2 and 1 (each within the scatter of the next); then compound 3.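

In this assay, the group on the sulfonyl sulfur clearly matters: 4-(trifluoromethoxy)phenyl in place of 2-(trifluoromethyl)phenyl gives a number 17 percentage points lower from compound 1 to compound 4 (beyond the scatter). Among these compounds, this is the first measured step at this position, and it shows that this part of the molecule, not only the other end of the shared core, can move the number. Nothing available explains the drop.

The change alters both the group and its numbered place on the phenyl, so the compounds shown cannot separate those two effects. Going by these compounds, whether an amine or a carboxylic acid on that phenyl would give a higher number also remains open.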